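A Trifluoromethyl Swap on a Weak Dopamine Transporter Binder

The source may hold more compounds than are shown below. What is called first, only, known or untested is meant among the compounds shown, and "the series" means these compounds.

Three measured compounds share one core, a sulfoxide carrying a diphenylmethyl group and a methylene-linked small aromatic ring. Compound 1 `Cc1noc(C[S+]([O-])C(c2ccccc2)c2ccccc2)n1` has a methyl group on a five-membered aromatic ring with two nitrogen and one oxygen; in an assay on HEK293 cells for inhibition of sodium-dependent dopamine transporter (Homo sapiens), read by scintillation counting, with stated times of 5 min and 1 min (on this read-out lower numbers stand for stronger inhibition and higher numbers for weaker inhibition), compound 1 gives 56700 nM. Compound 2 `Cc1cnc(C[S+]([O-])C(c2ccccc2)c2ccccc2)nc1` carries a different ring, and in this assay compound 2 gives 156000 nM, a change described by a 2.8-fold higher number from compound 1 to compound 2 (0.44 log units; beyond the scatter). Compound 3 `Cc1nnc(C[S+]([O-])C(c2ccccc2)c2ccccc2)s1` carries a third ring; in this assay compound 3 is reported only as "not active" (no number reported), without a number. Of the two numbers available, compound 1 has the lower one, so it stands as the stronger of the two.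

Compound 4 `[O-][S+](Cc1nc(C(F)(F)F)no1)C(c1ccccc1)c1ccccc1` differs from compound 1 by trifluoromethyl in place of methyl on an aromatic carbon. Among the measured compounds shown here, no measured step changes a substituent while keeping the ring, so the single step from compound 1 to compound 2 bears on this change only indirectly, showing that even a full ring exchange moved the number modestly. For compound 4 the expected step is a 1.0-fold lower number from compound 1 to compound 4 (0.01 log units; within the scatter), with compound 4 estimated at 55000 nM, ranging from 15000 nM to 200000 nM.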

Compound 4, half-maximal inhibitory concentration: 43700 nM
Compound 4: the middle estimate sits 1.3-fold (0.10 log units) above what was measured; the measured number falls inside the stated range.
By their numbers in this assay, from the lowest: compounds 4 and 1 (each within the scatter of the next); then compound 2.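

Compound 4 keeps the ring of compound 1 and changes only the group on this aromatic carbon, a kind of change the earlier ring exchanges could not isolate. In this assay the swap from methyl to trifluoromethyl, four heavy atoms in place of one, gives a 1.3-fold lower number from compound 1 to compound 4 (0.11 log units; within the scatter) and so leaves the two compounds indistinguishable on this read-out. Nothing shown here bears on the reason for this result.

The compounds shown leave open whether an amine, a carboxylic acid or a longer chain on this same aromatic carbon would shift the number beyond the scatter. They also leave open whether trifluoromethyl in place of methyl would read the same way on the ring of compound 2 or compound 3.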